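The source may hold more compounds than are shown below. What is called first, only, known or untested is meant among the compounds shown, and "the series" means these compounds.

Measured so far:
compound 1 `CCCN(CCC)CCCOc1ccc(C(=O)/C=C/c2ccccc2)cc1` — 1.91
compound 2 `CCCCN(CCCC)CCCCOc1ccc(C(=O)/C=C/c2ccccc2)cc1` — 2.09

Within the data shown here, in a physicochemical assay for lipophilicity, using the shake flask method, measured as octanol-water partition, at pH 7.4 (a higher number here means a more lipophilic compound, a lower number a more polar compound), compound 2 gives 2.09, the higher of the two numbers known, and compound 1 gives 1.91; the one known step, a number 0.18 log units higher from compound 1 to compound 2 (within the scatter), is within the scatter, so the two compounds cannot be told apart on this assay. Compound 3 `CN(C)CCCCCOc1ccc(C(=O)/C=C/c2ccccc2)cc1` has not yet been measured. It differs from compound 2 as follows: (dimethylamino)methyl in place of dibutylamino on a saturated chain carbon, four bonds along the chain from an oxygen on an aromatic ring. Among the measured compounds shown here, the one measured step, from compound 1 to compound 2, went the other way in kind — a larger dialkylamino group and a longer chain — and yet moved the partition coefficient only a little. The step to compound 3 removes considerably more carbon from the amine end than that step added, so on the same footing compound 3 is expected to come out lower in this assay, by a step of roughly a number 0.59 log units lower from compound 2 to compound 3 (beyond the scatter), though with little certainty about its size. For compound 3 the partition coefficient is estimated at 1.5, with a likely range from 1 to 2.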

Compound 3, partition coefficient: 1.73
Compound 3: the middle estimate sits 0.23 log units below what was measured; measured number inside the range.
By their numbers in this assay, from the lowest: compounds 3, 1 and 2 (each within the scatter of the next, the first and the last beyond it).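

In this assay, among these compounds, putting (dimethylamino)methyl in place of dibutylamino on a saturated chain carbon, four bonds along the chain from an oxygen on an aromatic ring, gives the one step so far that lies beyond the scatter: a number 0.36 log units lower from compound 2 to compound 3 (beyond the scatter) and that for an exchange in which 9 heavy atoms leave and 4 enter. Read as 2-(dimethylamino)ethyl in place of dipropylamino, the same kind of change gives a number 0.18 log units lower from compound 1 to compound 3 (within the scatter) and so leaves those two compounds indistinguishable on this read-out, which means that only compound 2 and compound 3 can be told apart among the three. No evidence is at hand on why the number moves as it does.

Going by these compounds, all three compounds end in an open-chain dialkylamino group, so the effect of a cyclic amine such as piperidine or morpholine at that end remains open. Also open, on these data alone, is what chain length does on its own, as the amine and the chain change together in every step here, and a longer chain carrying the same dimethylamino group would separate the two.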